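The source may hold more compounds than are shown below. What is called first, only, known or untested is meant among the compounds shown, and "the series" means these compounds.

Compound 1 `CCCSc1nc(N/N=C/c2cccnc2)c2nnn(Cc3ccccc3)c2n1` gives 58700 nM in a functional assay on MCF7 cells (Homo sapiens) for antiproliferative activity, read by MTT assay, with a stated time of 72 h; on this read-out higher numbers stand for weaker inhibition and lower numbers for stronger inhibition.
Compound 2 `CCCSc1nc(N/N=C/c2cc(OC)c(OC)c(OC)c2)c2nnn(Cc3ccccc3)c2n1` gives only a limit of this assay, > 64000 nM.
Compound 3 `CCCSc1nc(N/N=C(\C)c2ccccc2O)c2nnn(Cc3ccc(F)cc3)c2n1` also gives only a limit of this assay, > 64000 nM.

Among these three, compound 1 is the only one for which a number rather than a limit was recorded, and that number is itself high, which on this read-out means weak inhibition. Compounds 2 and 3 sit at the limit of > 64000 nM in this assay, at which 2 of the 3 values shown sit. Compound 4 `CCCSc1nc(N/N=C/c2ccc3ccccc3c2)c2nnn(Cc3ccccc3)c2n1` is not yet measured. It differs from compound 1 in a single place: naphthalen-2-yl in place of pyridin-3-yl on a carbon with a double bond to nitrogen. No two of the measured compounds differ in only one place, so none of them shows directly what such an exchange does. With every recorded result weak or at the limit, the step from compound 1 to compound 4 is expected to be small, without a clear direction beyond the usual scatter, and a 1.1-fold lower number from compound 1 to compound 4 (0.03 log units; within the scatter) is the expected size of that step. Compound 4 is therefore expected to give about 55000 nM in this assay, likely between 25000 nM and 130000 nM, with a fair chance that only a limit is reported.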

Compound 4, half-maximal inhibitory concentration: > 64000 nM
Compound 4: a limit, no number; the forecaster's own chance of this, stated with the estimate: 45%; middle value at least 1.1-fold (0.06 log units) away from the limit.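

Among the compounds shown here, the exchange of pyridin-3-yl for naphthalen-2-yl on a carbon with a double bond to nitrogen gives the first single-place comparison in this assay, and it reads as an at least 1.0-fold higher number from compound 1 to compound 4 (0.03 log units; that floor lies within the scatter). From the compounds shown here alone, the result for compound 4 is a limit and not a number, so this step is only a floor and its true size is unknown. Replacing the ring that holds a nitrogen with a larger, two-ring group of carbon only brings no recorded gain in inhibition, and compound 4 joins the compounds at the limit: the limit of > 64000 nM in this assay, at which 3 of the 4 values shown sit.

Going by these compounds, how far the number would rise with a measurable value for compound 4 stays open. Also open, on these data alone, is whether a non-aromatic group on this carbon, such as an amine, a carboxylic acid or a short alkyl chain, would bring the number clearly down.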